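The source may report more compounds than this note shows. Statements on the series, on what has been measured and on what is new or still open speak of the compounds shown alone.

Measured compounds:
compound 1 `CCC(=O)N1CCc2nc(C#Cc3ccccc3)sc2C1`, 38 nM
compound 2 `CC1CC(C(=O)N2CCc3nc(C#Cc4ccccc4)sc3C2)C1`, > 10000 nM
compound 3 `O=C(CC1CCOCC1)N1CCc2nc(C#Cc3ccccc3)sc2C1`, > 10000 nM

All three share one core and differ only in the group on the carbonyl carbon of the amide. In an assay on HEK293 cells for negative allosteric modulation of metabotropic glutamate receptor 5 (Homo sapiens), read by FLIPR, with a stated time of 1 h (on this read-out lower numbers stand for stronger inhibition and higher numbers for weaker inhibition), compound 1 gives 38 nM. For compound 2 the assay reports no number, only the limit > 10000 nM. For compound 3 it likewise reports only the limit > 10000 nM. On these data alone, compound 3 therefore sits at the weak end of everything measured so far, and its true position beyond that point is unknown; two of the three values sit at the limit of > 10000 nM in this assay, at which 2 of the 3 values shown sit.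

The readable steps are an at least 260-fold higher number from compound 1 to compound 2 (2.42 log units; beyond the scatter) and an at least 260-fold higher number from compound 1 to compound 3 (2.42 log units; beyond the scatter), while a step that the two limits leave unreadable from compound 2 to compound 3. Both larger groups on the carbonyl carbon drove the number past the limit.

Compound 4 `N#Cc1cccc(C(=O)N2CCc3nc(C#Cc4ccccc4)sc3C2)c1` is the next compound, differing from compound 3 by 3-cyanophenyl in place of (oxan-4-yl)methyl on a carbonyl carbon. The change keeps a group of similar size on the same carbonyl carbon, so a strong return toward compound 1 is not what the measured steps suggest, yet an aromatic group has not been tried and compound 3 is itself only a limit, so an at least 12-fold lower number from compound 3 to compound 4 (1.09 log units; beyond the scatter) is expected to be largely unreadable in direction. The expected value for compound 4 is 800 nM, within a range from 60 nM to 10000 nM.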

Compound 4, half-maximal inhibitory concentration: > 10000 nM
Compound 4: no number, only a limit (the forecaster's own chance of this, stated with the estimate: 30%); middle value at least 12-fold (1.09 log units) from the limit.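

In this assay compound 4 gives no number, only the limit > 10000 nM. For the compounds shown here, the one readable step is an at least 260-fold higher number from compound 1 to compound 4 (2.42 log units; beyond the scatter), so the loss seen with a saturated ring in the group on the carbonyl carbon now also appears with a six-membered aromatic ring of carbon only that carries a nitrile. The steps among compound 2, compound 3 and compound 4 cannot be read, so these three cannot be ranked against one another, and all that can be said is that they share one ceiling: (the limit of > 10000 nM in this assay, at which 3 of the 4 values shown sit).

Among the compounds shown, ethyl in compound 1 is the only group on the carbonyl carbon that gives a measured number, so it remains open how much larger that group can become before the number reaches the limit, which a propyl or cyclopropyl group could help to show. On these data alone, it also remains open whether an aromatic ring can work at this place at all, since a plain phenyl group without the nitrile, or a smaller ring such as furan, could give a number where compound 4 gives only a limit.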